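Replacing a piperazine amide with a sulfonamide-bearing chain

A few compounds are considered here, and "the series" means these few. Any claim that something is new, unique, unknown or untested is made for them only; others in the source may bear on it.

Measured so far:
- compound 1, `O=C(CN1CN(c2ccccc2)C2(CCN(C(=O)c3ccc(C4CCCCC4)cc3)CC2)C1=O)NCCCCO`: 10300 nM
- compound 2, `CC(C)(C)c1ccc(C(=O)N2CCC3(CC2)C(=O)N(CC(=O)N2CCNCC2)CN3c2ccccc2)cc1`: 22000 nM

Of the compounds shown here, two share a core and have been tested in an assay on HEK293 cells for displacement of a labelled ligand from NPC1-like intracellular cholesterol transporter 1 (Homo sapiens); a higher number here means a weaker inhibitor, a lower number a stronger inhibitor. Compound 1 gives 10300 nM, while compound 2 gives 22000 nM, the higher of the two numbers; the gap between them is beyond the usual scatter, so compound 2 is the weaker inhibitor of the pair. The two differ in several places at once, so no single change can be read from that gap.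

Compound 3, `CC(C)(C)c1ccc(C(=O)N2CCC3(CC2)C(=O)N(CC(=O)NCCCCCNS(C)(=O)=O)CN3c2ccccc2)cc1`, has not been measured. It keeps the core and the tert-butylphenyl amide of compound 2 and changes one place:
(5-(methanesulfonamido)pentyl)amino in place of piperazin-1-yl on a carbonyl carbon
Among the measured compounds shown here, no measured pair shows the effect of this change, so the expectation rests on the two values alone. The open chain in compound 3 resembles the chain in compound 1 more than the ring in compound 2 does, which suggests a somewhat lower number, though the step may fall within the scatter. For compound 3 the estimated value is 12000 nM, with a range of 4000 nM to 40000 nM, which would mean an expected step of a 1.8-fold lower number from compound 2 to compound 3 (0.26 log units; within the scatter).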

Compound 3, half-maximal inhibitory concentration: 5500 nM
Beside the measured number, compound 3's estimate is 2.2-fold (0.34 log units) above it, and the stated range covers the measured number.
By their numbers in this assay, from the lowest: compounds 3 and 1 (each within the scatter of the next); then compound 2.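

In this assay, among the compounds shown here, putting (5-(methanesulfonamido)pentyl)amino in place of piperazin-1-yl on a carbonyl carbon gives a 4.0-fold lower number from compound 2 to compound 3 (0.60 log units; beyond the scatter) and this is the first step that can be read from a change in one place. It shows that the number responds to what is attached to this carbonyl carbon, and that an open chain with no ring and 11 heavy atoms can replace a six-membered ring of 6 heavy atoms with a modest gain rather than a loss. Nothing measured here explains the step, so it cannot be assigned to the loss of the ring, the length of the chain or the methanesulfonamide at its end.

The compounds shown leave open which of these parts matters: a plain pentyl chain, a shorter propyl chain or a longer heptyl chain ending in the same methanesulfonamide, or a pentyl chain ending in a carboxylic acid or an acetamide, would begin to separate them. Going by these compounds, it also remains open whether the same chain would give a similar step with the 4-cyclohexylbenzoyl group of compound 1 in place of the tert-butylphenyl amide.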